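A few compounds are considered here, and "the series" means these few. Any claim that something is new, unique, unknown or untested is made for them only; others in the source may bear on it.

Compound 1 `COc1ccc(CC[C@H](O)C[C@@H](O)c2cc(-c3ccccc3)on2)cc1`: > 100000 nM
Compound 2 `COc1cccc(CC[C@H](O)C[C@@H](O)c2cc(-c3ccccc3)on2)c1`: > 100000 nM

In an ADME assay on HepG2 cells (Homo sapiens) for cytotoxicity, read by MTT assay, with a stated time of 24 h (on this read-out lower numbers stand for stronger inhibition and higher numbers for weaker inhibition), compound 1 gives > 100000 nM, which is a limit of the assay and not a number. Compound 2 gives > 100000 nM, also a limit. Compound 1 therefore stands at the limit of > 100000 nM in this assay, at which 2 of the 2 values shown sit, with no number to measure from.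

Compound 3 `COc1ccc(CC[C@H](O)C[C@H](O)c2cc(-c3ccccc3)on2)cc1` brings one change: the two compounds have the same atoms and bonds and differ only in configuration as drawn: 1 of 2 stereo elements differ; a stereocentre at a saturated chain carbon is drawn R in compound 1 and S in compound 3.

Among the measured compounds shown here, the only measured step is a step that the two limits leave unreadable from compound 1 to compound 2. For the measured compounds named here, it exchanges 4-methoxyphenyl for 3-methoxyphenyl and leaves configuration untouched, so no measured step covers this kind of change. The starting point is compound 1 at > 100000 nM, again a limit.

Expected here is a number no higher from compound 1 to compound 3 (the limit leaves the size open), meaning no step beyond the scatter in either direction. Compound 3 is estimated at 100000 nM, with an expected range of 50000 nM to 200000 nM.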

Compound 3, half-maximal inhibitory concentration: > 100000 nM
Compound 3 ended at the assay's limit; the forecaster's own chance of this, stated with the estimate: 85%; the middle value sits exactly at the limit.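

Compound 3, like compound 1, gives only a limit in this assay, so the step between these two compounds cannot be read. The compounds shown leave open whether the configuration as drawn changes this read-out at all, with every value resting on one limit: the limit of > 100000 nM in this assay, at which 3 of the 3 values shown sit.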